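Chain extension on the amide of compound 1

This account rests on a few compounds, and the source may have more. Where it says the series, first, only, none or still open, it means among the compounds named here.

Compound 1 `O=C(CCc1ccccc1)Nc1nc2ccccc2c(=O)s1` carries a phenyl two saturated carbons away from the amide carbonyl. In an assay on CHO cells for displacement of a labelled ligand from adenosine receptor A2b (Homo sapiens), read by scintillation counting, with a stated time of 75 min (a higher number here means a weaker inhibitor, a lower number a stronger inhibitor), compound 1 gives 365 nM, the lowest of the two numbers reported, with compound 3 `COc1cccc(/C=C/C(=O)Nc2nc3ccccc3c(=O)s2)c1` close by at 679 nM, a gap within the scatter. Compound 2 `Cc1sc2nc(NC(=O)CCCc3ccccc3)sc(=O)c2c1C`, built on a different core, reaches only the limit > 1000 nM in this assay, which is a limit rather than a number; this is the limit of > 1000 nM in this assay, at which 1 of the 3 values shown sits.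

Compound 4 `O=C(CCCc1ccccc1)Nc1nc2ccccc2c(=O)s1` differs from compound 1 by benzyl in place of phenyl on a saturated chain carbon, two bonds along the chain from a carbonyl carbon. For the measured compounds named here, no measured pair in this set shows a step of that kind on the shared core, so the direction is open. The account expects at most a modest step in this assay, on the weaker side if any, from compound 1 to compound 4 of a 1.6-fold higher number from compound 1 to compound 4 (0.22 log units; within the scatter). Compound 4 is therefore estimated at 600 nM in this assay, within a range from 200 nM to 2500 nM.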

Compound 4, inhibition constant: > 1000 nM
Compound 4: no number, only a limit; the forecaster's own chance of this, stated with the estimate: 25%; at least 1.6-fold (0.22 log units) between middle value and limit.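

Benzyl in place of phenyl on a saturated chain carbon, two bonds along the chain from a carbonyl carbon, gives an at least 2.7-fold higher number from compound 1 to compound 4 (0.43 log units; beyond the scatter) in this assay. For the compounds shown here, this is the first step read on the shared core, and it shows that this position does not tolerate the change without loss: the longer chain moves the number beyond the scatter, and on the weaker side. Compound 4 gives only a limit, not a number, and so joins the compounds recorded at that limit: the limit of > 1000 nM in this assay, at which 2 of the 4 values shown sit.

From the compounds shown here alone, the true size of the step stays open, since one end of it is a limit. Also open, going by these compounds, is how a shorter chain, or an ether oxygen within the chain, would read on the shared core in this assay.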